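Swapping 2,4-dichlorophenyl for 3,4-dichlorophenyl in compound 3

The compounds below may be only part of what the source reports. "The series", "measured", "known", "first", "only" and "open" are said of these compounds alone.

Compound 1 `CN1C/C(=C\c2ccc(Cl)cc2)C(=O)/C(=C/c2cccc([N+](=O)[O-])c2)C1`: > 20000 nM, a limit of the assay
Compound 2 `CN1C/C(=C\c2cccc([N+](=O)[O-])c2)C(=O)/C(=C/c2ccc(Cl)cc2Cl)C1`: 14000 nM

Going by the values given here, in an ADME assay on L02 cells (Homo sapiens) for cytotoxicity, read by MTT assay, with a stated time of 24 h (on this read-out higher numbers stand for weaker inhibition and lower numbers for stronger inhibition), compound 2 gives 14000 nM, the only actual number so far. Compound 1 stands at > 20000 nM, which is a limit and not a number.

Compound 3 `CN1C/C(=C\c2cccc([N+](=O)[O-])c2)C(=O)/C(=C/c2ccc(Cl)c(Cl)c2)C1` is the next structure to consider, and the change is 3,4-dichlorophenyl in place of 2,4-dichlorophenyl on a double-bonded chain carbon bound to a double-bonded ring carbon. Its atoms are those of compound 2, joined differently.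

Among the compounds with values here, one measured step bears on this group: an at least 1.4-fold lower number from compound 1 to compound 2 (0.15 log units; that floor lies within the scatter). Since that step's floor lies within the scatter, it gives no firm size or direction for a change on this aromatic group, so no step beyond the scatter is expected in this assay. The expected size is no change at the digits printed from compound 2 to compound 3 (within the scatter). The estimate for compound 3 is 14000 nM, with an expected range from 7000 nM to 28000 nM.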

Compound 3, half-maximal inhibitory concentration: 14800 nM
Compound 3: middle estimate off by 1.1-fold (0.02 log units), on the low side, and the stated range covers the measured number.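

In this assay, going by these compounds alone, exchanging 2,4-dichlorophenyl for 3,4-dichlorophenyl on a double-bonded chain carbon bound to a double-bonded ring carbon gives a 1.1-fold higher number from compound 2 to compound 3 (0.02 log units; within the scatter), so this is the first pair with two actual numbers, and the two dichlorophenyl groups cannot be told apart here. The other new step, an at least 1.3-fold lower number from compound 1 to compound 3 (0.13 log units; that floor lies within the scatter), offers only a floor that gives no firm size or direction. Compound 1 is a limit and not a number, so that step has no upper end: the limit of > 20000 nM in this assay, at which 1 of the 3 values shown sits.

The compounds shown leave open whether any change on this aromatic group can move the number beyond the scatter. On these data alone, whether an amine or a carboxylic acid on that ring would do so remains unknown, as does the effect of replacing the nitro group.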